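Adding a Phenyl Ring and Toxicity to Vero Cells

This account rests on a few compounds, and the source may have more. Where it says the series, first, only, none or still open, it means among the compounds named here.

Three compounds have so far been tested in an ADME assay on Vero cells (Chlorocebus sabaeus) for cytotoxicity, read by sulforhodamine B assay, with a stated time of 72 h; on this read-out higher numbers stand for weaker inhibition and lower numbers for stronger inhibition:
compound 1 `CN1CCc2cc(-c3ccccc3)ccc2C1` gives > 50000 nM, which is a limit of the assay and not a number.
compound 2 `CN1CCc2cc(-c3ccc(-c4ccccc4)cc3)ccc2C1` gives 15600 nM.
compound 3 `CN1Cc2c(OCc3ccccc3)cccc2[C@@H](O)C1` gives > 100000 nM, which is a limit of the assay and not a number.

Compound 1 sits at the limit of > 50000 nM in this assay, at which 1 of the 3 values shown sits, and compound 3 sits at the limit of > 100000 nM in this assay, at which 1 of the 3 values shown sits. Compound 2 is the only one of the three with an actual number.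

Compound 1 and compound 2 differ in one place: phenyl in place of hydrogen on an aromatic carbon. That single change produced an at least 3.2-fold lower number from compound 1 to compound 2 (0.50 log units; beyond the scatter), so the added ring made the compound more toxic to the cells.

Compound 4 `CN1Cc2c(OCc3ccc(-c4ccccc4)cc3)cccc2[C@@H](O)C1` is the unmeasured compound. It differs from compound 3 in exactly the same way: phenyl in place of hydrogen on an aromatic carbon. The two descriptions of the place are identical word for word, so this is the same change, made on a different core. How the core of compound 3 differs from the core of compound 1 is not broken down here.

Because the step of an at least 3.2-fold lower number from compound 1 to compound 2 (0.50 log units; beyond the scatter) was at least modest, a step of similar size is expected from compound 3 to compound 4, that is an at least 2.5-fold lower number from compound 3 to compound 4 (0.39 log units; beyond the scatter). Since compound 3 only gives a limit, compound 4 is still expected to be a weak inhibitor, estimated at 40000 nM, between 12000 nM and 120000 nM.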

Compound 4, half-maximal inhibitory concentration: > 50000 nM
Compound 4: a limit, no number; the forecaster's own chance of this, stated with the estimate: 35%; middle value at least 1.2-fold (0.09 log units) away from the limit.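

Among the compounds shown here, compound 3 and compound 4 both end at a limit of this assay and not at a number, so the step between them cannot be read, and no new step comes from this result. The compounds shown leave open whether phenyl in place of hydrogen on an aromatic carbon lowers the number on the core of compound 3, as it did on the core of compound 1.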